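A few compounds are considered here, and "the series" means these few. Any claim that something is new, unique, unknown or untested is made for them only; others in the source may bear on it.

Measured so far in a functional assay on Vero cells (Chlorocebus sabaeus) for cytotoxicity (a lower number here means a stronger inhibitor, a higher number a weaker inhibitor), each entry being a limit of the assay:
Compound 1 `Nc1nc(=O)n([C@H]2C=C[C@@H](CO)O2)cc1Br` gives > 100000 nM
Compound 2 `Nc1nc(=O)n([C@H]2C=C[C@@H](CO)O2)cc1I` gives > 100000 nM
Compound 3 `CC(=O)OC[C@@H]1C=C[C@H](n2cc(F)c(N)nc2=O)O1` gives > 100000 nM

Compound 3 stands only at a limit, with > 100000 nM as its entry and no number behind it. The whole measured set looks the same, with the limit of > 100000 nM in this assay, at which 3 of the 3 values shown sit, as the full picture so far. Compound 4 `CCCCC(=O)OC[C@@H]1C=C[C@H](n2cc(F)c(N)nc2=O)O1` differs from compound 3 in one place, with propyl in place of hydrogen on a saturated chain carbon bound to a carbonyl carbon as the change, which can also be read as acetoxy to (butylcarbonyl)oxy. For the measured compounds named here, the one measured step is a step that the two limits leave unreadable from compound 1 to compound 2 and has no readable size. It also lies at the halogen and not at the acetoxy group, so it gives no guide to this change. In this assay no change beyond the scatter is therefore expected, and no direction can be assigned. This expectation rests on compound 3 with its limit of > 100000 nM as the only anchor. The expected step is a number no higher from compound 3 to compound 4 (the limit leaves the size open) in size. For compound 4 the estimated value is 100000 nM with an expected range from 50000 nM to 150000 nM and the assay may well report only a limit again.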

Compound 4, half-maximal inhibitory concentration: > 100000 nM
Compound 4 ended at the assay's limit (the forecaster's own chance of this, stated with the estimate: 80%); the middle value lies on the limit itself.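

Compound 3 and compound 4 both stand only at a limit in this assay, so no step can be read between them. The compounds shown leave open whether any of these changes alters the read-out at all, as the whole set sits at one value: the limit of > 100000 nM in this assay, at which 4 of the 4 values shown sit.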